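Cytotoxicity of an aryl amine change on the shared core

This account rests on a few compounds, and the source may have more. Where it says the series, first, only, none or still open, it means among the compounds named here.

Among the measured compounds shown here, in an ADME assay on THP-1 cells (Homo sapiens) for cytotoxicity (on this read-out lower numbers stand for higher toxicity in this test and higher numbers for lower toxicity in this test), compound 2 `Cc1ccc2nc(-c3ccccn3)c(Nc3ccc(F)cc3)n2c1` gives 9610 nM, which is the single number reported there. Compound 1 `c1ccc(-c2nc3ccccn3c2NCC2CCO2)nc1` returns a limit of the assay rather than a number, > 50000 nM; it sits at the limit of > 50000 nM in this assay, at which 1 of the 2 values shown sits. Compound 3 `COc1cccc(Nc2c(-c3ccccn3)nc3ccc(C)cn23)c1` differs from compound 2 by 3-methoxyphenyl in place of 4-fluorophenyl on a nitrogen on an aromatic ring. For the measured compounds named here, no measured pair differs in one place, so the step from compound 2 to compound 3 is expected to stay within the usual scatter, with no direction favoured: a 1.2-fold higher number from compound 2 to compound 3 (0.10 log units; within the scatter). Compound 3 is therefore estimated at 12000 nM, between 4000 nM and 40000 nM.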

Compound 3, half-maximal cytotoxic concentration: 13200 nM
Compound 3: the middle estimate sits 1.1-fold (0.04 log units) below what was measured; the measured number falls inside the stated range.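

Among the compounds shown here, the pair gives the first reading at this position: with 3-methoxyphenyl in place of 4-fluorophenyl on a nitrogen on an aromatic ring, this assay shows a 1.4-fold higher number from compound 2 to compound 3 (0.14 log units; within the scatter). One substituted phenyl can therefore replace the other here without moving the read-out beyond the scatter, even though the entering group counts one hydrogen-bond acceptor and the leaving group none. Nothing in the data shown explains this small step. Going by these compounds, whether a phenyl ring carrying an amine or a carboxylic acid on this nitrogen would move the read-out beyond the scatter remains open.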